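A few compounds are considered here, and "the series" means these few. Any claim that something is new, unique, unknown or untested is made for them only; others in the source may bear on it.

In an ADME assay on CCRF-CEM cells (Homo sapiens) for cytotoxicity, with a stated time of 3 days (on this read-out lower numbers stand for higher toxicity in this test and higher numbers for lower toxicity in this test), compound 1 `O=C(OC1C=CC(n2ccc(=O)n(Cc3ccccc3)c2=O)C1)c1ccccc1` gives > 25000 nM, and this is a limit of the assay rather than a number. Going by the values given here, compound 2 `Cc1cc(=O)n(C(=O)c2ccccc2)c(=O)n1C1C=CC(OC(=O)c2ccccc2)C1` gives 191000 nM, the only actual number so far, so there is no measured step to rank it by. Compound 3 `O=C(OC1C=CC(n2ccc(=O)n(C(=O)c3ccccc3)c2=O)C1)c1ccccc1` differs from compound 2 in one place: hydrogen in place of methyl on an aromatic carbon. Among the compounds with values here, with no measured step to guide it, the expected change is small, with none beyond the scatter, and the estimated step is a 1.6-fold lower number from compound 2 to compound 3 (0.20 log units; within the scatter). For compound 3 the estimated value is 120000 nM, with an expected range from 40000 nM to 300000 nM.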

Compound 3, half-maximal cytotoxic concentration: >= 250000 nM
Compound 3: only a limit was reported (the forecaster's own chance of this, stated with the estimate: 35%); middle value at least 2.0-fold (0.31 log units) away from the limit.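

In this assay, compound 3 is reported only as a limit rather than a number: >= 250000 nM. Hydrogen in place of methyl on this aromatic carbon, next to the ring nitrogen, gives an at least 1.3-fold higher number from compound 2 to compound 3 (0.11 log units; that floor lies within the scatter), so removing the methyl shows no sign of raising toxicity in this test, though the full size of the step remains unknown. The step between compound 1 and compound 3 cannot be read, as both values are limits.

On these data alone, whether an ethyl or an amine on this carbon would shift the number remains open.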